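Compound 1 and a larger group on the aromatic nitrogen

The source may report more compounds than this note shows. Statements on the series, on what has been measured and on what is new or still open speak of the compounds shown alone.

Measured in an ADME assay on microsomes from liver (Homo sapiens) for pharmacokinetics; a higher number here means faster removal of the compound, a lower number slower removal:
- compound 1 `Cc1nn(C2COC2)cc1Nc1nc(N)c2c(C#N)c(N3CCC[C@H]3C)n(C)c2n1`: 46.7 mL/min/kg
- compound 2 `C[C@@H]1CCCN1c1c(C#N)c2c(N)nc(Nc3cn(C)nc3Cl)nc2n1C`: 183 mL/min/kg

Of these two compounds, compound 1 has the lower number in this assay. Compound 3 `Cc1nn(CC2(O)COC2)cc1Nc1nc(N)c2c(C#N)c(N3CCC[C@H]3C)n(C)c2n1` has not yet been measured. It keeps the core of compound 1 and carries (3-hydroxyoxetan-3-yl)methyl in place of oxetan-3-yl on an aromatic nitrogen.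

For the measured compounds named here, only one measured step bears on this change, and only loosely. The step of a 3.9-fold higher number from compound 1 to compound 2 (0.59 log units; beyond the scatter) lies beyond the scatter, but it replaces the whole 3-methyl-1-(oxetan-3-yl)-1H-pyrazol-4-yl group with 3-chloro-1-methyl-1H-pyrazol-4-yl. Going by the values given here, no measured pair isolates a change on the aromatic nitrogen alone, and none shows the effect of the added atoms. Compound 3 still has a four-membered non-aromatic ring in the entering group, so a step as large as the measured one is not expected. The expected step is small, a 1.2-fold lower number from compound 1 to compound 3 (0.07 log units; within the scatter), and is not expected to exceed the scatter. The estimate for compound 3 is 40 mL/min/kg, with an expected range of 18 mL/min/kg to 85 mL/min/kg.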

Compound 3, clearance: 76.7 mL/min/kg
Beside the measured number, compound 3's estimate is 1.9-fold (0.28 log units) below it; the measured number falls inside the stated range.
By their numbers in this assay, from the lowest: compounds 1 and 3 (each within the scatter of the next); then compound 2.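

In this assay, for the compounds shown here, this is the first pair that differs only in the group on the aromatic nitrogen, and it gives a 1.6-fold higher number from compound 1 to compound 3 (0.22 log units; within the scatter), so compound 1 and compound 3 cannot be told apart here. With the whole 3-methyl-1-(oxetan-3-yl)-1H-pyrazol-4-yl group replaced, the earlier comparison gave a 3.9-fold higher number from compound 1 to compound 2 (0.59 log units; beyond the scatter) and lay beyond the scatter, whereas exchanging oxetan-3-yl for (3-hydroxyoxetan-3-yl)methyl at this one position, with the four-membered non-aromatic ring kept and a hydrogen-bond donor added, does not produce a step beyond the scatter. No measurement available here accounts for the size of either step.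

The compounds shown leave open whether an amine or a carboxylic acid in place of the hydroxy group of (3-hydroxyoxetan-3-yl)methyl would also stay within the scatter of compound 1. They also leave open what a longer chain on the aromatic nitrogen, or a plain 2-hydroxyethyl group without the four-membered ring, would do in this assay on the same core.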